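Compound 4: a dibromo-hydroxyphenyl variant of compound 3

The source may report more compounds than this note shows. Statements on the series, on what has been measured and on what is new or still open speak of the compounds shown alone.

Three compounds sharing one core were tested in a functional assay on BGC-823 cells (Homo sapiens) for cytotoxicity, read by MTT assay, with a stated time of 48 h; on this read-out lower numbers stand for stronger inhibition and higher numbers for weaker inhibition. Compound 1 `O=C(CSc1nnc(-c2ccncc2)o1)N/N=C/c1ccc([N+](=O)[O-])cc1` gives 31500 nM, compound 2 `Cc1ccc(/C=N/NC(=O)CSc2nnc(-c3ccncc3)o2)cc1` gives 21800 nM, and compound 3 `COc1cccc(/C=N/NC(=O)CSc2nnc(-c3ccncc3)o2)c1` gives 15800 nM. Compound 3 holds the lowest of the three numbers, yet both gaps stay within the scatter: a 2.0-fold lower number from compound 1 to compound 3 (0.30 log units; within the scatter) and a 1.4-fold lower number from compound 2 to compound 3 (0.14 log units; within the scatter). Compound 4 `O=C(CSc1nnc(-c2ccncc2)o1)N/N=C/c1cc(Br)cc(Br)c1O` differs from compound 3 by 3,5-dibromo-2-hydroxyphenyl in place of 3-methoxyphenyl on a carbon with a double bond to nitrogen. Within the data shown here, the steps that bear on this change are those same two swaps of the ring on the carbon with a double bond to nitrogen, neither of which moved beyond the scatter in this assay. A step of similar size, a 1.3-fold lower number from compound 3 to compound 4 (0.12 log units; within the scatter), is therefore expected in this assay. Compound 4 is estimated at 12000 nM, within 4000 nM to 40000 nM.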

Compound 4, half-maximal inhibitory concentration: 9610 nM
The estimate for compound 4 lay 1.2-fold (0.10 log units) above the measured number; the range from low to high includes it.
By their numbers in this assay, from the lowest: compounds 4, 3, 2 and 1 (each within the scatter of the next, the first and the last beyond it).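

In this assay, swapping the ring on the carbon with a double bond to nitrogen first moved the number beyond the scatter with 3,5-dibromo-2-hydroxyphenyl, modestly so in a 2.3-fold lower number from compound 2 to compound 4 (0.36 log units; beyond the scatter) and in a 3.3-fold lower number from compound 1 to compound 4 (0.52 log units; beyond the scatter). Against 3-methoxyphenyl the same group stays within the scatter, at a 1.6-fold lower number from compound 3 to compound 4 (0.22 log units; within the scatter), so compound 3 and compound 4 cannot be told apart. No measurement at hand accounts for these steps. The bromine atoms and the hydroxyl enter together, and the compounds shown leave open what each contributes alone. Also open, going by these compounds, is how an amine or a carboxylic acid on this ring would read.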